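Bis(trifluoromethyl)benzenesulfonamide series: benzyl variation notes

The compounds below may be only part of what the source reports. "The series", "measured", "known", "first", "only" and "open" are said of these compounds alone.

Of the compounds shown here, two have numbers so far. Compound 1 `O=S(=O)(NCCNCc1cccc2ccccc12)c1cc(C(F)(F)F)cc(C(F)(F)F)c1` in a functional assay on MIA PaCa-2 cells (Homo sapiens) for inhibition, read by MTT assay, with a stated time of 72 h (a higher number here means a weaker inhibitor of growth, a lower number a stronger inhibitor of growth), gives 26000 nM. Compound 2 `O=S(=O)(NCCCNCc1ccccc1Cl)c1cc(C(F)(F)F)cc(C(F)(F)F)c1`, which carries a three-carbon chain and a 2-chlorobenzyl group, gives 11000 nM in this assay. For the measured compounds named here, on these two numbers compound 2 stands lowest; the only neighbour, compound 1, lies higher and the gap between them is beyond the usual scatter. Compound 1 and compound 2 differ in more than one place, so their two values are all that can be said of that pair.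

Compound 3 `CC(C)(C)c1ccc(CNCCCNS(=O)(=O)c2cc(C(F)(F)F)cc(C(F)(F)F)c2)cc1` is not yet measured. It differs from compound 2 by 4-(tert-butyl)phenyl in place of 2-chlorophenyl on a saturated chain carbon bound to an amine nitrogen. Going by the values given here, no measured pair shows this change, so nothing fixes its size. The expectation is a small step downward, possibly within the scatter, a 1.6-fold lower number from compound 2 to compound 3 (0.20 log units; within the scatter). Compound 3 is therefore estimated at 7000 nM in this assay, with a range from 2500 nM to 20000 nM.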

Compound 3, concentration for 50% growth inhibition: 2300 nM
The estimate for compound 3 lay 3.0-fold (0.48 log units) above the measured number; measured number outside the range, below it.
By their numbers in this assay, from the lowest: compound 3; then compound 2; then compound 1.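

The change of 2-chlorobenzyl to 4-(tert-butyl)benzyl, on a saturated chain carbon bound to an amine nitrogen, gives the series its first single-place step: in this assay there is a 4.8-fold lower number from compound 2 to compound 3 (0.68 log units; beyond the scatter), so the number at this place depends on the aryl group carried there. The change removes the chlorine and brings in the tert-butyl group in one move, so the step belongs to the pair of groups as a whole and cannot be divided between them. For the compounds shown here, nothing measured so far accounts for the size of the step.

The compounds shown leave open whether a 4-chlorobenzyl or a 4-methoxybenzyl group would give a similar number. They also leave open whether the 4-(tert-butyl)benzyl group would behave the same way on a longer chain.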